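Nitro in place of hydrogen on compound 3

This account rests on a few compounds, and the source may have more. Where it says the series, first, only, none or still open, it means among the compounds named here.

Measured in a functional assay on 786-0 cells (Homo sapiens) for inhibition, read by sulforhodamine B assay, with a stated time of 48 h (a lower number here means a stronger inhibitor of growth, a higher number a weaker inhibitor of growth), so far:
- compound 1 `CCOC(=O)c1nn(-c2ccccc2)c(-c2ccc([N+](=O)[O-])cc2)c1CNC(C)(C)C` gives 200000 nM; > 545000 nM (2 entries)
- compound 2 `CC(C)(C)NCc1c(C(=O)O)nn(-c2ccccc2)c1-c1ccc(Cl)cc1` gives > 652000 nM
- compound 3 `CC(C)(C)NCc1c(C(=O)O)nn(-c2ccccc2)c1-c1ccccc1` gives > 716000 nM

Compound 3 stands only at a limit (> 716000 nM) and offers no number to step from. Compound 2 also stands only at a limit (> 652000 nM) in the same read-out.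

Compound 4 `CC(C)(C)NCc1c(C(=O)O)nn(-c2ccccc2)c1-c1ccc([N+](=O)[O-])cc1` follows from compound 3 by nitro in place of hydrogen on an aromatic carbon, para to a large group (nitro in place of hydrogen on an aromatic carbon), which reads as phenyl to 4-nitrophenyl.

For the measured compounds named here, the one measured step on such a carbon is a step that the two limits leave unreadable from compound 2 to compound 3 and gives no size to carry over. The 4-nitrophenyl group is already present in compound 1, and the record there is the several entries of compound 1 in this assay, 200000 nM; > 545000 nM (2 entries) with the second entry a limit.

Given the limit for compound 3 (> 716000 nM) no step beyond the scatter is expected in this assay and no direction can be named. The expected size is an at least 1.1-fold lower number from compound 3 to compound 4 (0.07 log units; that floor lies within the scatter) as a loose estimate resting mainly on limits. A report as a limit is the likeliest outcome for the next measurement. For compound 4 the estimated value is 600000 nM with an expected range from 200000 nM to 1000000 nM in this series.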

Compound 4, concentration for 50% growth inhibition: > 634000 nM
Compound 4 ended at the assay's limit; the forecaster's own chance of this, stated with the estimate: 80%; middle value at least 1.0-fold (0.02 log units) away from the limit.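

In this assay compound 4 gives > 634000 nM, a limit and not a number. Compound 3 gives > 716000 nM, also a limit. Compound 2 gives > 652000 nM, again a limit. For the compounds shown here, no step among compound 2, compound 3 and compound 4 can be read. The compounds shown leave open whether nitro, chloro or hydrogen on that aromatic carbon makes any difference to growth inhibition.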